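Vero cell cytotoxicity: estimate for compound 4

A few compounds are considered here, and "the series" means these few. Any claim that something is new, unique, unknown or untested is made for them only; others in the source may bear on it.

Compound 1 `CCOc1ccc(C(=O)/C=C/c2ccc(C(=O)Nc3cccc(-c4cc(C(=O)OC)no4)c3)cc2)cc1` is read in an ADME assay on Vero cells (Chlorocebus sabaeus) for cytotoxicity, read by MTT assay, with a stated time of 72 h; a lower number here means that less compound is tolerated, a higher number that more compound is tolerated. In this assay compound 1 gives > 40 ug/mL, which is a limit of the assay rather than a number. Compound 2 `COC(=O)c1cc(-c2cccc(NC(=O)c3ccc(OCc4ccc(Cl)cc4)cc3)c2)on1` also reaches only a limit there, > 80 ug/mL. Compound 3 `COC(=O)c1cc(-c2cccc(NC(=O)c3ccc(/C=C/C(=O)c4ccc(C)c([N+](=O)[O-])c4)cc3)c2)on1` likewise gives a limit, > 80 ug/mL. The step that the two limits leave unreadable from compound 1 to compound 3 is consequently not readable between the two limits. Compound 4 `COC(=O)c1cc(-c2cccc(NC(=O)c3ccc(/C=C/C(=O)c4ccc(F)cc4F)cc3)c2)on1` differs from compound 1 by 2,4-difluorophenyl in place of 4-ethoxyphenyl on a carbonyl carbon. Going by the values given here, no measured step gives a readable size for such a change; the single step at the same carbonyl carbon, a step that the two limits leave unreadable from compound 1 to compound 3, ends at the limit of > 80 ug/mL in this assay, at which 2 of the 3 values shown sit, while compound 1 itself sits at the limit of > 40 ug/mL in this assay, at which 1 of the 3 values shown sits. Compound 4 is therefore expected to stay at a limit as well, with the step that the limit leaves unreadable from compound 1 to compound 4 not expected to exceed the scatter. For compound 4 the estimate is 80 ug/mL, within 40 ug/mL to 160 ug/mL.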

Compound 4, half-maximal cytotoxic concentration: > 40 ug/mL
Compound 4: no number, only a limit (the forecaster's own chance of this, stated with the estimate: 85%); the middle value is on the limit's open side.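

In this assay compound 4 gives > 40 ug/mL, a limit of the assay and not a number. The steps to compound 4 from compound 1, compound 2 and compound 3 cannot be read. The compounds shown leave open where any actual cytotoxic concentration lies, and whether the group on the carbonyl carbon changes it.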